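Chloro for hydrogen on the anilide ring of compound 1

The source may hold more compounds than are shown below. What is called first, only, known or untested is meant among the compounds shown, and "the series" means these compounds.

Measured so far:
compound 1, `O=C(Nc1ccccc1)c1cccc2oc(=O)[nH]c12`, 2200 nM
compound 2, `Cc1cccc(NC(=O)c2cccc3oc(=O)[nH]c23)c1`, 109 nM

In an assay on isolated protein for binding affinity to metabotropic glutamate receptor 5 (Homo sapiens) (on this read-out higher numbers stand for weaker inhibition and lower numbers for stronger inhibition), compound 1 gives the highest of the two numbers, with compound 2 as its nearest neighbour at a lower value. For the measured compounds named here, the only single-point step that has been measured, a 20-fold lower number from compound 1 to compound 2 (1.30 log units; beyond the scatter), was large and came from methyl in place of hydrogen on an aromatic carbon of the anilide ring.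

Compound 3, `O=C(Nc1ccccc1Cl)c1cccc2oc(=O)[nH]c12`, has not yet been measured in this assay. It differs from compound 1 by chloro in place of hydrogen on an aromatic carbon. The measured step from compound 1 to compound 2 bears on it only loosely: it shows that a small substituent on this ring can move the number a great deal, but chloro is a different group from methyl and enters ortho to a large group, so the size of the earlier step cannot simply be carried over. Compound 3 is expected to show a 2.8-fold lower number from compound 1 to compound 3 (0.44 log units; beyond the scatter), which would be a step downward beyond the scatter and smaller than a 20-fold lower number from compound 1 to compound 2 (1.30 log units; beyond the scatter). Compound 3 is therefore estimated at 800 nM, with a range from 150 nM to 4000 nM.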

Compound 3, inhibition constant: > 10000 nM
Compound 3: a limit, no number (the forecaster's own chance of this, stated with the estimate: 5%); middle value at least 12-fold (1.09 log units) away from the limit.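

In this assay, compound 3 stands at a limit of the assay and not at a number: the limit of > 10000 nM in this assay, at which 1 of the 3 values shown sits. The limit still fixes a direction, with an at least 4.5-fold higher number from compound 1 to compound 3 (0.65 log units; beyond the scatter), whereas the earlier step was a 20-fold lower number from compound 1 to compound 2 (1.30 log units; beyond the scatter), so adding a substituent to the anilide ring of compound 1 does not by itself lower the number. Chloro ortho to a large group thus brings weaker inhibition in this assay, a change in the opposite direction to the only one the earlier compounds had shown.

Compound 2 and compound 3 differ both in the group and in where it sits, so the compounds shown cannot tell whether the reversal belongs to chloro or to its place on the ring. On these data alone, it remains open whether methyl, fluoro or methoxy ortho to a large group would also raise the number, and whether chloro at the place held by the methyl of compound 2 would lower it as that methyl does.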